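The source may report more compounds than this note shows. Statements on the series, on what has been measured and on what is new or still open speak of the compounds shown alone.

In a functional assay on NCI-H460 cells (Homo sapiens) for antiproliferative activity, read by MTT assay, with a stated time of 48 h (on this read-out lower numbers stand for stronger inhibition and higher numbers for weaker inhibition), compound 1 `COc1ccccc1C(=O)Nc1nnc(SCC(=O)Nc2ccc(Br)cn2)s1` gives only a limit, > 80000 nM. Compound 2 `COc1ccccc1C(=O)Nc1nnc(SCC(=O)Nc2ccc(C)cn2)s1` likewise returns only a limit in this assay, > 80000 nM. The change from compound 1 to compound 2 is methyl in place of bromo on an aromatic carbon, and its step, a step that the two limits leave unreadable from compound 1 to compound 2, cannot be sized because both values sit at the limit of > 80000 nM in this assay, at which 2 of the 3 values shown sit. Compound 3 `O=C(CSc1nnc(NC(=O)CCl)s1)Nc1ccc(Br)cn1` does give a number in this assay, 7500 nM. The cores of compound 1 and compound 3 differ by chloromethyl in place of 2-methoxyphenyl on a carbonyl carbon, and that difference gives an at least 10-fold lower number from compound 1 to compound 3 (1.02 log units; beyond the scatter). Among the compounds with values here, compound 4 `Cc1ccc(NC(=O)CSc2nnc(NC(=O)CCl)s2)nc1` carries the same change as the one from compound 1 to compound 2, here (methyl in place of bromo on an aromatic carbon), at a place described in identical words. Resting on compound 3 at 7500 nM and on the unreadable earlier step, compound 4 is expected to take a step of a 1.6-fold higher number from compound 3 to compound 4 (0.20 log units; within the scatter). Compound 4 is therefore estimated at 12000 nM, between 3500 nM and 45000 nM.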

Compound 4, half-maximal inhibitory concentration: 15400 nM
Compound 4: middle estimate off by 1.3-fold (0.11 log units), on the low side, within the range that was stated.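

In this assay, methyl in place of bromo can be read on one core only, as a 2.1-fold higher number from compound 3 to compound 4 (0.31 log units; beyond the scatter); the matching step between compound 1 and compound 2 cannot be read, as both of those values are limits: the limit of > 80000 nM in this assay, at which 2 of the 4 values shown sit.

Chloromethyl in place of 2-methoxyphenyl gives a lower number on both cores, the second case being an at least 5.1-fold lower number from compound 2 to compound 4 (0.71 log units; beyond the scatter): the same change on two cores in this assay, an at least 10-fold lower number (1.02 log units; beyond the scatter) from compound 1 to compound 3 and an at least 5.1-fold lower number (0.71 log units; beyond the scatter) from compound 2 to compound 4; the limit leaves it open whether they differ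

This shows that the direction of that change carries from the bromo compounds to the methyl compounds, but not that its size does, and it gives no second reading for methyl in place of bromo.

The compounds shown leave open what an amine or a nitrile at that ring carbon would give in this assay. They also leave open the effect of a longer chain in place of chloromethyl.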